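Sulfonamide Change on a Shared Core: Expected Clearance

The source may hold more compounds than are shown below. What is called first, only, known or untested is meant among the compounds shown, and "the series" means these compounds.

Compound 1, `Cc1ccc(S(=O)(=O)N(C)CC(C)C)cc1C#Cc1cc(Cl)ccc1OCC(=O)O`: 119 mL.min-1.g-1
Compound 2, `CCCS(=O)(=O)c1ccc(F)c(C#Cc2cc(Cl)ccc2OCC(=O)O)c1`: < 10 mL.min-1.g-1 (a limit of the assay)

Both compounds were run in an in vitro ADME assay on microsomes from liver (Rattus norvegicus) for metabolic stability, read by LC-MS, tested at 1 uM; a higher number here means faster removal of the compound, a lower number slower removal. Compound 1 gives 119 mL.min-1.g-1, the only plain number shown in this assay. Compound 2 returns < 10 mL.min-1.g-1, which is a limit of the assay rather than a number, as recorded in the limit of < 10 mL.min-1.g-1 in this assay, at which 1 of the 2 values shown sits. Going by the values given here, no step between two measured compounds that differ in one place is available, so the size of such a change in this assay is unknown from these data.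

Compound 3, `COCCNS(=O)(=O)c1ccc(C)c(C#Cc2cc(Cl)ccc2OCC(=O)O)c1`, has not yet been measured. It differs from compound 1 in one place: (2-methoxyethyl)amino in place of isobutyl(methyl)amino on a sulfonyl sulfur.

Compound 3 is expected to show slower removal than compound 1, by an estimated step of a 3.0-fold lower number from compound 1 to compound 3 (0.47 log units; beyond the scatter) that lies beyond the usual scatter. The estimate for compound 3 in this assay is 40 mL.min-1.g-1, expected to fall between 15 mL.min-1.g-1 and 100 mL.min-1.g-1.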

Compound 3, intrinsic clearance in microsomes: < 10 mL.min-1.g-1
Compound 3: only a limit was reported; the forecaster's own chance of this, stated with the estimate: 15%; middle value at least 4.0-fold (0.60 log units) away from the limit.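

In this assay the sulfonyl sulfur turns out to be a place where one change alone gives an at least 11-fold lower number from compound 1 to compound 3 (1.07 log units; beyond the scatter) when (2-methoxyethyl)amino stands in place of isobutyl(methyl)amino. Going by these compounds alone, this is the first step between measured compounds that differ in one place, and it shows that a change at this position can be large. The reading for compound 3 is a limit of the assay and not a number, so the full size of the step cannot be read: the limit of < 10 mL.min-1.g-1 in this assay, at which 2 of the 3 values shown sit.

The compounds shown leave open which part of the change carries the step: the ether oxygen, the hydrogen on the sulfonamide nitrogen or the loss of the isobutyl and methyl groups. They also leave open how a plain methylamino group or a morpholine would behave on the same sulfur.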